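Swapping thiophen-3-yl for pyridin-2-yl on compound 2

A few compounds are considered here, and "the series" means these few. Any claim that something is new, unique, unknown or untested is made for them only; others in the source may bear on it.

In a functional assay on cardiac atrium (Cavia porcellus) (a lower number here means that less compound is needed, a higher number that more compound is needed for the effect), compound 1 `COC(=O)C1=C(C)NC(C)=C(C(=O)OC)C1c1c(-c2ccccn2)nc2sccn12` gives 24400 nM and compound 2 `COC(=O)C1=C(C)NC(C)=C(C(=O)OC)C1c1c(-c2ccsc2)nc2sc(C)cn12` gives 2300 nM as the lower of the two numbers, a gap beyond the usual scatter. Compound 3 `COC(=O)C1=C(C)NC(C)=C(C(=O)OC)C1c1c(-c2ccccn2)nc2sc(C)cn12` is still unmeasured. For the measured compounds named here, it departs from compound 2 by pyridin-2-yl in place of thiophen-3-yl on an aromatic carbon and no measured step isolates this change. A rise in this assay beyond the scatter is expected, since compound 1 also carries pyridin-2-yl and stands at 24400 nM on the high side. The expected move is a 3.5-fold higher number from compound 2 to compound 3 (0.54 log units; beyond the scatter) on this estimate. Compound 3 is estimated at 8000 nM within an expected range of 2500 nM to 25000 nM overall.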

Compound 3, half-maximal effective concentration: 39900 nM
Estimate against measurement, compound 3: 5.0-fold (0.70 log units) below, and the stated range ends below it.
By their numbers in this assay, from the lowest: compound 2; then compounds 1 and 3 (each within the scatter of the next).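

In this assay, pyridin-2-yl in place of thiophen-3-yl on this aromatic carbon gives a large step, a 17-fold higher number from compound 2 to compound 3 (1.24 log units; beyond the scatter), so this position responds strongly to the choice of ring. By contrast, methyl in place of hydrogen on the other aromatic carbon gives a 1.6-fold higher number from compound 1 to compound 3 (0.21 log units; within the scatter), so with pyridin-2-yl present that methyl shifts nothing beyond the scatter. Nothing measured here accounts for the size of the ring step. As far as these compounds go, it remains open whether phenyl or pyridin-3-yl at this position would stand closer to thiophen-3-yl or to pyridin-2-yl, and whether the methyl matters with thiophen-3-yl present.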